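This account rests on a few compounds, and the source may have more. Where it says the series, first, only, none or still open, it means among the compounds named here.

Measured so far in an assay on cells for inhibition of alkaline phosphatase, tissue-nonspecific isozyme (Homo sapiens), read by luminescence, with stated times of 7 min and 20 min; on this read-out higher numbers stand for weaker inhibition and lower numbers for stronger inhibition:
compound 1 `CCCCNc1nn2c(=O)cc(C(F)(F)F)nc2s1` – 880 nM
compound 2 `CCCCCNc1nn2c(=O)cc(C(F)(F)F)nc2s1` – 610 nM
compound 3 `COc1ccccc1-c1nn2c(=O)cc(C(F)(F)F)nc2s1` – 3480 nM

Compound 3 stands highest of the three numbers in this assay; compound 1 gives 880 nM and compound 2 gives 610 nM, both well below it. Going by the values given here, the only single-point step among the measured compounds is a 1.4-fold lower number from compound 1 to compound 2 (0.16 log units; within the scatter), which concerns a saturated chain on the shared core and lies within the scatter.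

Compound 4 `O=c1cc(C(F)(F)F)nc2sc(-c3ccccc3F)nn12` differs from compound 3 by fluoro in place of methoxy on an aromatic carbon. Among the compounds with values here, no measured step touches an aromatic substituent on this ring, so nothing among the measured compounds bears directly on this change; the one step that exists, a 1.4-fold lower number from compound 1 to compound 2 (0.16 log units; within the scatter), was small and concerns a different part of the molecule. With no guidance, the expectation is a number near that of compound 3, with no step beyond the scatter in either direction and a wide range. Compound 4 is therefore expected at 3200 nM, between 1000 nM and 10000 nM. This amounts to an expected 1.1-fold lower number from compound 3 to compound 4 (0.04 log units; within the scatter).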

Compound 4, half-maximal inhibitory concentration: > 100000 nM
Compound 4: no number, only a limit (the forecaster's own chance of this, stated with the estimate: 10%); at least 31-fold (1.49 log units) between middle value and limit.
By their numbers in this assay, from the lowest: compounds 2 and 1 (each within the scatter of the next); then compound 3. At a limit, above all of these: compound 4.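

In this assay, compound 4 carries only a limit and not a number: the limit of > 100000 nM in this assay, at which 1 of the 4 values shown sits. Going by these compounds alone, the substituent on the aromatic ring, which no earlier step touched, proves decisive: with fluoro in place of methoxy, ortho to a large group, the result is an at least 28-fold higher number from compound 3 to compound 4 (1.45 log units; beyond the scatter). The gaps to the amino compounds are wider, at an at least 160-fold higher number from compound 2 to compound 4 (2.21 log units; beyond the scatter) and an at least 110-fold higher number from compound 1 to compound 4 (2.05 log units; beyond the scatter), yet compound 3 shows that an aromatic ring at that place can still give a measurable value, so the ring alone does not set the loss.

Going by these compounds, whether the change reflects the loss of methoxy or the entry of fluoro stays open; an unsubstituted phenyl, or a hydroxy or ethoxy group at the same place, would separate the two. Whether a longer chain such as hexylamino would move the number also remains unresolved.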